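Ortho-substituent exchange on the triazole-linked phenyl ring

The source may report more compounds than this note shows. Statements on the series, on what has been measured and on what is new or still open speak of the compounds shown alone.

Compound 2 `O=C(Nc1cccc(OCc2cn(-c3ccccc3Br)nn2)c1)Nc1ccc(Cl)c(C(F)(F)F)c1`: 2810 nM
Compound 1 `CC(C)c1cccc(-n2cc(COc3cccc(NC(=O)Nc4ccc(Cl)c(C(F)(F)F)c4)c3)nn2)c1`: 3250 nM

For the measured compounds named here, in a functional assay on HepG2 cells (Homo sapiens) for inhibition, read by MTT assay, with a stated time of 72 h (a lower number here means a stronger inhibitor, a higher number a weaker inhibitor), compound 2 gives 2810 nM, the lowest of the two numbers so far, with compound 1 giving 3250 nM; the step of a 1.2-fold lower number from compound 1 to compound 2 (0.06 log units; within the scatter) lies within the scatter. Compound 3 `O=C(Nc1cccc(OCc2cn(-c3ccccc3C(F)(F)F)nn2)c1)Nc1ccc(Cl)c(C(F)(F)F)c1` differs from compound 2 by trifluoromethyl in place of bromo on an aromatic carbon. Going by the values given here, no measured step concerns this exact exchange; the only step seen, a 1.2-fold lower number from compound 1 to compound 2 (0.06 log units; within the scatter), changed the same aryl group with little effect. A step within the scatter is therefore expected, a 1.0-fold higher number from compound 2 to compound 3 (0.01 log units; within the scatter). Compound 3 is estimated at 2900 nM, in the range 1200 nM to 7000 nM.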

Compound 3, half-maximal inhibitory concentration: 2320 nM
For compound 3 the middle estimate is 1.3-fold (0.10 log units) above the measured one, and the stated range covers the measured number.
By their numbers in this assay, from the lowest: compounds 3, 2 and 1 (each within the scatter of the next).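

In this assay trifluoromethyl in place of bromo, ortho to a large group, gives a small change (a 1.2-fold lower number from compound 2 to compound 3 (0.08 log units; within the scatter)), so this place accepts either group with no shift beyond the scatter. The 2-(trifluoromethyl)phenyl in place of 3-isopropylphenyl also gives a small change (a 1.4-fold lower number from compound 1 to compound 3 (0.15 log units; within the scatter)), leaving all three aryl groups shown within the scatter of one another. Nothing available explains why these exchanges change so little. The compounds shown leave open whether an amine or a carboxylic acid at this place would shift the number beyond the scatter.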